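Working notes: from compound 2 to compound 3

The source may hold more compounds than are shown below. What is called first, only, known or untested is meant among the compounds shown, and "the series" means these compounds.

In a functional assay on HL-60 cells (Homo sapiens) for antiproliferative activity, read by MTT assay, with a stated time of 72 h (a higher number here means a weaker inhibitor, a lower number a stronger inhibitor), compound 1 (`COc1cc(-c2ncnn2-c2cccc(F)c2)cc(OC)c1OC`) reaches only a limit of the assay, > 10000 nM. Within the data shown here, compound 2 (`COc1cc(-n2ncnc2-c2ccc(C)cc2)cc(OC)c1OC`) gives 90 nM in this assay, the only actual number so far. Compound 3 (`COc1cccc(-c2ncnn2-c2cc(OC)c(OC)c(OC)c2)c1`) carries 3-methoxyphenyl in place of 4-methylphenyl on an aromatic carbon. Among the measured compounds shown here, no measured pair isolates this change, so the expectation remains loose. The estimated step is a 6.7-fold higher number from compound 2 to compound 3 (0.82 log units; beyond the scatter), towards weaker inhibition. The estimate for compound 3 is 600 nM. The expected range for compound 3 runs from 80 nM to 6000 nM.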

Compound 3, half-maximal inhibitory concentration: > 10000 nM
Compound 3 was reported as a limit (the forecaster's own chance of this, stated with the estimate: 15%); at least 16-fold (1.22 log units) between middle value and limit.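

In this assay, 3-methoxyphenyl in place of 4-methylphenyl on an aromatic carbon gives an at least 110-fold higher number from compound 2 to compound 3 (2.04 log units; beyond the scatter), so the activity of compound 2 depends strongly on the aryl group at this position. Compound 3 stands at a limit of the assay, > 10000 nM, so this step is a lower bound and its full size cannot be read: the limit of > 10000 nM in this assay, at which 2 of the 3 values shown sit.

Going by these compounds, whether the drop follows from the entering methoxy group or from the loss of the methyl group stays open. A plain phenyl group on this carbon would help separate the two.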